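Taking the ring-bearing group off compound 3

The source may report more compounds than this note shows. Statements on the series, on what has been measured and on what is new or still open speak of the compounds shown alone.

In a physicochemical assay for metabolic stability, read by LC-MS, in phosphate buffer, with a stated time of 120 min, at pH 7.4, tested at 1 uM (a lower number here means that less of the compound is left, a higher number that more of the compound is left), compound 1 (`CC#CCn1c(N2CCC[C@@H](N)C2)nc2c1c(=O)n(Cc1ccc(Br)cc1C(=O)OC)c(=O)n2C`) gives 99.4% and compound 2 (`CC#CCn1c(N2CCC[C@@H](N)C2)nc2c1c(=O)n(Cc1ccc(Br)cc1C(=O)OCC)c(=O)n2C`) gives 98.4%. The two are separated only by a number 1 percentage points lower from compound 1 to compound 2 (within the scatter). Compound 3 (`CC#CCn1c(N2CCC[C@@H](N)C2)nc2c1c(=O)n(Cc1ccc(Br)cc1C(=O)OCc1oc(=O)oc1C)c(=O)n2C`) gives 8.32%, the lowest of the three numbers. Its distance from the other two is large, as shown by a number 91.1 percentage points lower from compound 1 to compound 3 (beyond the scatter) and by a number 90.1 percentage points lower from compound 2 to compound 3 (beyond the scatter).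

The change that leads to compound 4 (`CC#CCn1c(N2CCC[C@@H](N)C2)nc2c1c(=O)n(Cc1ccc(Br)cc1C(=O)O)c(=O)n2C`) is a hydrogen atom in place of a group of 8 heavy atoms (5 carbon, 3 oxygen; one five-membered aromatic ring with 2 hetero atoms), on an oxygen next to a carbonyl group, on an oxygen next to a carbonyl group. Within the data shown here, no measured step makes this exact change, and no measured compound has hydrogen on that oxygen, so the comparison is indirect. The closest evidence is the pair of large steps into compound 3, both of which bring in the five-membered aromatic ring. The swap of hydrogen for methyl, a number 1 percentage points lower from compound 1 to compound 2 (within the scatter), stays within the scatter. Compound 4 has no such ring, like compound 1 at 99.4% and compound 2 at 98.4%. A large rise is therefore expected, and the estimated step is a number 88.7 percentage points higher from compound 3 to compound 4 (beyond the scatter). Compound 4 is expected at 97%, with an estimated range from 86% to 102%.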

Compound 4, percent of the compound remaining: 99.2%
For compound 4 the middle estimate is 2.2 percentage points below the measured one, and the stated range covers the measured number.
By their numbers in this assay, from the lowest: compound 3; then compounds 2, 4 and 1 (each within the scatter of the next).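

Among these compounds, with hydrogen on the oxygen next to a carbonyl group, in place of the group of 8 heavy atoms that holds the five-membered aromatic ring, this assay gives a number 90.9 percentage points higher from compound 3 to compound 4 (beyond the scatter), and this is the first direct look at this oxygen with nothing attached to it. Bare hydrogen there stands level with the small chains, as a number 0.8 percentage points higher from compound 2 to compound 4 (within the scatter) and a number 0.2 percentage points lower from compound 1 to compound 4 (within the scatter) both show, so among these four compounds the low number goes with the ring-bearing group alone and not with whether that oxygen carries a chain at all. Nothing given here explains why that group has so large an effect on the read-out, or shows what compound 3 turns into during the test.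

The compounds shown leave open how a longer chain such as propyl or butyl on this oxygen, or an amine in its place, would behave. They also leave open which part of the group of 8 heavy atoms goes with the low number, since the group appears only as a whole and in compound 3 alone.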